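This account rests on a few compounds, and the source may have more. Where it says the series, first, only, none or still open, it means among the compounds named here.

Compound 2 `CCCNc1nc(=O)c2cc(C(F)(F)F)cc([N+](=O)[O-])c2s1` carries a propylamino group on the shared core. In an ADME assay on Vero cells (Chlorocebus sabaeus) for cytotoxicity, read by MTT assay, with a stated time of 72 h (on this read-out lower numbers stand for stronger inhibition and higher numbers for weaker inhibition), compound 2 gives only a limit of the assay, > 100000 nM. Compound 1 `CCNc1nc(=O)c2cc(C(F)(F)F)cc([N+](=O)[O-])c2s1` is its ethylamino counterpart. In this assay compound 1 likewise gives only a limit, > 100000 nM. The step that the two limits leave unreadable from compound 1 to compound 2 therefore cannot be read, and the limit of > 100000 nM in this assay, at which 2 of the 2 values shown sit, is all that the two measured compounds show. Compound 3 `CC(C)CNc1nc(=O)c2cc(C(F)(F)F)cc([N+](=O)[O-])c2s1` differs from compound 2 by methyl in place of hydrogen on a saturated chain carbon bound to two saturated chain carbons. Within the data shown here, only that unreadable step bears on this change, so from the numbers in hand no direction and no size beyond the scatter can be foreseen in this assay; the most that can be said is that both measured compounds stand at the limit. Compound 3 is therefore expected to stay at that same limit, with an estimated step that the limit leaves unreadable from compound 2 to compound 3. For compound 3 the estimate is 150000 nM, within the range 60000 nM to 400000 nM.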

Compound 3, half-maximal inhibitory concentration: > 100000 nM
Compound 3: only a limit was reported (the forecaster's own chance of this, stated with the estimate: 85%); the middle value lies beyond the limit too.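

Compound 3, like compound 1 and compound 2, gives only a limit in this assay, so the steps among these three compounds cannot be read: the limit of > 100000 nM in this assay, at which 3 of the 3 values shown sit.

The compounds shown leave open how far the true values lie beyond that limit, and whether changing the amino chain on the shared core shifts them at all.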